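Swapping the aryl group on the saturated ring: compound 3

A few compounds are considered here, and "the series" means these few. Any claim that something is new, unique, unknown or untested is made for them only; others in the source may bear on it.

Measured so far:
Compound 1, `COc1ccc(-n2nc(Sc3ccc(Cl)cc3)cc(CC[C@@H](C)NC(=O)[C@H]3CNCC[C@@H]3c3ccc(Cl)cc3)c2=O)cc1`, gives 2.4 nM in an assay on CHO cells for binding affinity to Melanocortin receptor 4 (Homo sapiens); a lower number here means a stronger inhibitor, a higher number a weaker inhibitor.
Compound 2, `COc1ccc(-n2nc(Sc3ccc(Cl)cc3)cc(CC[C@@H](C)NC(=O)[C@H]3CNCC[C@@H]3c3cccc(C(F)(F)F)c3)c2=O)cc1`, gives 100 nM in this assay.

For the measured compounds named here, compound 2 stands at the highest of the two numbers, the step of a 42-fold higher number from compound 1 to compound 2 (1.62 log units; beyond the scatter) being the only measured change. Compound 3, `COc1ccc(-n2nc(Sc3ccc(Cl)cc3)cc(CC[C@@H](C)NC(=O)[C@H]3CNCC[C@@H]3c3cccc4ccccc34)c2=O)cc1`, differs from compound 2 by naphthalen-1-yl in place of 3-(trifluoromethyl)phenyl on a saturated ring carbon. Going by the values given here, no measured pair shares this exact change, but the one step that exists, a 42-fold higher number from compound 1 to compound 2 (1.62 log units; beyond the scatter), shows that the group on this saturated ring carbon can move the number a great deal, and that the trifluoromethyl-bearing group of compound 2 sits at the weak end. Among the compounds with values here, since only one step is known, the expectation rests on loose ground; compound 3 is expected to improve somewhat on compound 2, by a 4.0-fold lower number from compound 2 to compound 3 (0.60 log units; beyond the scatter), giving an estimated 25 nM with a range from 4 nM to 150 nM.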

Compound 3, half-maximal inhibitory concentration: 89 nM
For compound 3 the middle estimate is 3.6-fold (0.55 log units) below the measured one; the range from low to high includes it.
By their numbers in this assay, from the lowest: compound 1; then compounds 3 and 2 (each within the scatter of the next).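

In this assay, the step of a 1.1-fold lower number from compound 2 to compound 3 (0.05 log units; within the scatter) lies within the scatter, so at this saturated ring carbon the two-ring naphthalen-1-yl and the one-ring 3-(trifluoromethyl)phenyl cannot be told apart. Naphthalen-1-yl in place of 4-chlorophenyl gives a 37-fold higher number from compound 1 to compound 3 (1.57 log units; beyond the scatter), so a second, quite different replacement also ends far from compound 1, and among these three compounds only the 4-chlorophenyl group gives a low number. No measurement at hand explains this difference between the groups.

From the compounds shown here alone, what remains open is whether the chlorine itself matters or also where it sits on the ring, which 3-chlorophenyl at this carbon would help to separate. The compounds shown also leave open how far a plain phenyl or a 4-fluorophenyl group would hold the number of compound 1.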